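The compounds below may be only part of what the source reports. "The series", "measured", "known", "first", "only" and "open" are said of these compounds alone.

Of the compounds shown here, two of a shared core have been measured in a functional assay on U-87MG ATCC cells (Homo sapiens) for cytotoxicity, read by MTT assay, with a stated time of 72 h; a lower number here means a stronger inhibitor, a higher number a weaker inhibitor. Compound 1 `COc1cc2c(Oc3ccc(NC(=O)c4nnn(-c5ccc(F)c(F)c5)c4C(F)(F)F)cc3F)ccnc2cc1OCCCN1CCC(C)CC1` gives 1150 nM in this assay. Compound 2 `COc1cc2c(Oc3ccc(NC(=O)c4nnn(-c5ccccc5Cl)c4C(F)(F)F)cc3F)ccnc2cc1OCCCN1CCN(C)CC1` gives 1220 nM in this assay. Compound 2 sits alongside compound 1 in this assay: the gap between the two numbers is within the usual scatter of repeated measurements, so neither can be called the stronger or the weaker inhibitor of the pair.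

Compound 3 `COc1cc2c(Oc3ccc(NC(=O)c4nnn(-c5ccc(F)c(F)c5)c4C(F)(F)F)cc3F)ccnc2cc1OCCCN1CCN(C)CC1` has not yet been measured in this assay. It differs from compound 2 in one place: 3,4-difluorophenyl in place of 2-chlorophenyl on an aromatic nitrogen. Put in words, 3,4-difluorophenyl takes the place of 2-chlorophenyl on an aromatic nitrogen. Compound 1 already carries the 3,4-difluorophenyl group, though on a different tail, and its number in this assay lies within the scatter of that of compound 2, so no step beyond the scatter is expected from compound 2 to compound 3 in this assay. The expected step of a 1.0-fold lower number from compound 2 to compound 3 (0.01 log units; within the scatter) is therefore essentially none. Compound 3 is estimated at 1200 nM in this assay, with a range from 500 nM to 3000 nM.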

Compound 3, half-maximal inhibitory concentration: 1390 nM
Beside the measured number, compound 3's estimate is 1.2-fold (0.06 log units) below it; measured number inside the range.
By their numbers in this assay, from the lowest: compounds 1, 2 and 3 (each within the scatter of the next).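

In this assay, 3,4-difluorophenyl in place of 2-chlorophenyl on an aromatic nitrogen of the five-membered ring gives a 1.1-fold higher number from compound 2 to compound 3 (0.06 log units; within the scatter), so with the 4-methylpiperazin-1-yl tail in place, this swap of one substituted phenyl ring for another leaves no readable difference. The tail can now be read on its own as well: with the 3,4-difluorophenyl group held constant, 4-methylpiperazin-1-yl in place of 4-methylpiperidin-1-yl gives a 1.2-fold higher number from compound 1 to compound 3 (0.08 log units; within the scatter), again a step within the usual scatter. Compound 1 and compound 2 differ in two places, so two opposing effects could have hidden behind their close numbers, whereas these two single-place steps show that neither change, taken alone, moves the number beyond the scatter.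

Nothing measured here explains why these numbers stay so close. Still open, as far as these compounds go, is whether this position would respond to a plain phenyl ring, a pyridine ring or a phenyl ring carrying a carboxylic acid or an amine, and whether the tail would respond to a morpholine ring or a shorter chain.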